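Dithioester anilino series: one chloro removed from the aryl ring

This account rests on a few compounds, and the source may have more. Where it says the series, first, only, none or still open, it means among the compounds named here.

Measured so far in a functional assay on PBMC cells (Homo sapiens) for inhibition, read by thymidine incorporation, with a stated time of 72 h; a lower number here means a stronger inhibitor, a higher number a weaker inhibitor:
- compound 1 `CC1(C)CC(=O)C(C(=S)SCCO)=C(Nc2ccc(Cl)cc2Cl)C1`: > 50 ug/mL (a limit of the assay, not a number)
- compound 3 `CC1(C)CC(=O)C(C(=S)SCCO)=C(Nc2ccc(Cl)cc2)C1`: 21 ug/mL
- compound 2 `CC(=O)OC[C@H]1O[C@@H](SC(=S)C2=C(Nc3ccc(Cl)cc3Cl)CC(C)(C)CC2=O)[C@H](OC(C)=O)[C@@H](OC(C)=O)[C@@H]1OC(C)=O`: 15.8 ug/mL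

Compound 1 sits at the assay limit (the limit of > 50 ug/mL in this assay, at which 1 of the 3 values shown sits). Compound 3 differs from compound 1 only by hydrogen in place of chloro on an aromatic carbon, and this step reads an at least 2.3-fold lower number from compound 1 to compound 3 (0.37 log units; beyond the scatter). Because compound 1 only reaches a limit, the true size of that step is unknown; it may be larger than the figure shown.

Compound 2 carries the same 2,4-dichlorophenyl amino group on a different core, and the difference between the two cores is not broken down here. Compound 2 gives the lowest number of the two measured in this assay, but its gap to compound 3 is within the scatter, so no order between them is claimed.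

Compound 4 `CC(=O)OC[C@H]1O[C@@H](SC(=S)C2=C(Nc3ccc(Cl)cc3)CC(C)(C)CC2=O)[C@H](OC(C)=O)[C@@H](OC(C)=O)[C@@H]1OC(C)=O` is the unmeasured partner of compound 2, differing by hydrogen in place of chloro on an aromatic carbon. This is the same change as from compound 1 to compound 3, with the same surroundings at the place of change. The expectation for compound 4 therefore rests on the step seen from compound 1 to compound 3 an at least 2.3-fold lower number from compound 1 to compound 3 (0.37 log units; beyond the scatter), with the caution that this step starts from a limit and that the cores differ. Compound 4 is expected to show a step of a 2.0-fold lower number from compound 2 to compound 4 (0.30 log units; within the scatter) in this assay. The estimate for compound 4 is 8 ug/mL, with a range from 3 ug/mL to 25 ug/mL.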

Compound 4, half-maximal inhibitory concentration: 9.9 ug/mL
Beside the measured number, compound 4's estimate is 1.2-fold (0.09 log units) below it, and the stated range covers the measured number.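

In this assay, the step on the core of compound 2 reads a 1.6-fold lower number from compound 2 to compound 4 (0.20 log units; within the scatter), so removing this chloro does not separate the pair on this core. Set beside the step on the core of compound 1, the change shows no reversal of direction, but the two steps cannot be called equal or different in size: the same change on two cores in this assay, an at least 2.3-fold lower number (0.37 log units; beyond the scatter) from compound 1 to compound 3 and a 1.6-fold lower number (0.20 log units; within the scatter) from compound 2 to compound 4; the limit leaves it open whether they differ The earlier step also starts from a limit and not a number, so these compounds do not support carrying a step size from one core to the other: the limit of > 50 ug/mL in this assay, at which 1 of the 4 values shown sits.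

The aryl group appears only as 2,4-dichlorophenyl and 4-chlorophenyl, which leaves open how an unsubstituted phenyl, a 4-fluorophenyl or a 4-methoxyphenyl group would read on either core. Going by these compounds alone, the group on sulfur appears in only two forms, the hydroxyethyl chain and the one in compound 2, so a longer chain ending in a carboxylic acid or an amine also remains open.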